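Sulfonamide series: aryl-to-pyridyl exchange on the amide carbonyl

The compounds below may be only part of what the source reports. "The series", "measured", "known", "first", "only" and "open" are said of these compounds alone.

Measured so far:
Compound 1 `O=C(c1ccc(Cl)cc1)N1CCC(NS(=O)(=O)c2cc(S(=O)(=O)c3ccccc3)ccc2C(F)(F)F)CC1` — 300 nM
Compound 2 `O=C(c1ccc(C(F)(F)F)cc1)N1CCC(NS(=O)(=O)c2cc(S(=O)(=O)c3ccccc3)ccc2C(F)(F)F)CC1` — 400 nM
Compound 3 `O=C(c1ccccn1)N1CCC(NS(=O)(=O)c2cc(S(=O)(=O)c3ccccc3)ccc2C(F)(F)F)CC1` — 60 nM

All three share one core and differ only in the group on the carbonyl carbon of the piperidine amide. In an assay on isolated protein for displacement of a labelled ligand from secreted frizzled-related protein 1 (Homo sapiens), read by fluorescence polarization, with a stated time of 30 min (a lower number here means a stronger inhibitor, a higher number a weaker inhibitor), compound 2 gives the highest number of the three; compound 1 sits nearest, with a 1.3-fold higher number from compound 1 to compound 2 (0.12 log units; within the scatter), and compound 3 sits furthest, with a 6.7-fold lower number from compound 2 to compound 3 (0.82 log units; beyond the scatter).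

Compound 4 `O=C(c1cccnc1)N1CCC(NS(=O)(=O)c2cc(S(=O)(=O)c3ccccc3)ccc2C(F)(F)F)CC1` is not yet measured. Its change from compound 2 is pyridin-3-yl in place of 4-(trifluoromethyl)phenyl on a carbonyl carbon.

Within the data shown here, the steps that bear on this are the two aryl-to-pyridyl exchanges already seen: a 5.0-fold lower number from compound 1 to compound 3 (0.70 log units; beyond the scatter) and a 6.7-fold lower number from compound 2 to compound 3 (0.82 log units; beyond the scatter), both beyond the scatter and both toward lower numbers. Among the measured compounds shown here, compound 4 carries a pyridin-3-yl rather than the pyridin-2-yl of compound 3, and no measured pair shows how those two differ, so the size for compound 4 is less certain than for compound 3. A lower number than compound 2 is nonetheless expected for compound 4, of the order of a 3.3-fold lower number from compound 2 to compound 4 (0.52 log units; beyond the scatter). Compound 4 is estimated at 120 nM, with a range from 45 nM to 350 nM.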

Compound 4, half-maximal inhibitory concentration: 80 nM
Beside the measured number, compound 4's estimate is 1.5-fold (0.18 log units) above it; low and high end bracket the measured number.
By their numbers in this assay, from the lowest: compounds 3 and 4 (each within the scatter of the next); then compounds 1 and 2 (each within the scatter of the next).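

In this assay the move to lower numbers seen with pyridin-2-yl on this carbonyl carbon also holds for pyridin-3-yl, with a 5.0-fold lower number from compound 2 to compound 4 (0.70 log units; beyond the scatter) and a 3.8-fold lower number from compound 1 to compound 4 (0.57 log units; beyond the scatter) both beyond the scatter. The two pyridyl groups are not separated, since a 1.3-fold higher number from compound 3 to compound 4 (0.12 log units; within the scatter) lies within the scatter and they cannot be ranked here. Across these four compounds, then, both pyridyl groups give lower numbers than both substituted phenyl groups, and no compound shown goes against this.

No measurement shown accounts for this difference between the pyridyl and substituted phenyl groups. From the compounds shown here alone, it remains open whether pyridin-4-yl, plain phenyl or a saturated ring carrying an amine, placed on the same carbonyl carbon, would fall with the pyridyl compounds or with the substituted phenyl compounds.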